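The source may hold more compounds than are shown below. What is called first, only, known or untested is meant among the compounds shown, and "the series" means these compounds.

Two compounds from this series have been examined in a functional assay on cardiac atrium for agonist activity at histamine H2 receptor (Cavia porcellus); on this read-out higher numbers stand for larger maximal responses and lower numbers for smaller maximal responses. Compound 1, `COc1ccc(C(CC/N=C(\N)NCCCc2c[nH]cn2)c2ccccn2)cc1`, is a full agonist on that read-out: in this assay compound 1 gives 1. Compound 2, `N=C(NCCCc1c[nH]cn1)NCCC(c1ccc(C(F)(F)F)cc1)c1ccccn1`, is also close to full: in this assay compound 2 gives 0.9. Compound 2 thus stands at a number that the usual scatter does not separate from that of compound 1; the two results together point to a shared core that supports near-maximal responses in this assay regardless of which aryl group sits on the saturated chain carbon.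

The next compound is compound 3, `N=C(NCCCc1c[nH]cn1)NCCC(c1ccccn1)c1ccccn1`. It differs from compound 2 in one place: pyridin-2-yl in place of 4-(trifluoromethyl)phenyl on a saturated chain carbon bound to an aromatic carbon and a saturated chain carbon. Because compound 2 already gives 0.9 and compound 1 gives 1, both with aryl groups of different character at the same place, the step from compound 2 to compound 3 is expected to be small, with no change beyond the scatter, a number 0.050 higher from compound 2 to compound 3 (within the scatter). Compound 3 is therefore estimated to give 0.95 in this assay, within a range from 0.75 to 1.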

Compound 3, intrinsic activity: the largest response reached, as a fraction of the reference agonist's: 1
Estimate against measurement, compound 3: 0.050 below, and the stated range covers the measured number.
By their numbers in this assay, from the lowest: compounds 2, 1 and 3 (each within the scatter of the next).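

In this assay, pyridin-2-yl in place of 4-(trifluoromethyl)phenyl on a saturated chain carbon bound to an aromatic carbon and a saturated chain carbon gives a number 0.10 higher from compound 2 to compound 3 (within the scatter), so this single change leaves the maximal response within the scatter. It shows that, with the rest of the structure held fixed, this position accepts a ring with 1 hetero atom and 1 hydrogen-bond acceptor, 6 heavy atoms in all, as well as an all-carbon ring bearing trifluoromethyl, with 10 heavy atoms and no hydrogen-bond acceptor. Nothing at hand explains why the response holds across this change.

As far as these compounds go, whether the response holds with a group other than an aromatic ring at this place, such as cyclohexyl or a plain methyl, or with an amine or a carboxylic acid carried on the aryl ring, stays open. The maximal response also leaves open how much of each compound is needed to reach it, so the compounds could still differ in that respect.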